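Fluoro to Methoxy on a Chalcone-Type Growth Inhibitor

This account rests on a few compounds, and the source may have more. Where it says the series, first, only, none or still open, it means among the compounds named here.

Measured compounds:
compound 1, `COc1ccc(-c2nc3ccccn3c2/C=C/C(=O)c2cc(OC)c(OC)c(OC)c2)cc1`: 9330 nM
compound 2, `COc1cc(C(=O)/C=C/c2c(-c3ccc(F)cc3)nc3ncccn23)cc(OC)c1OC`: 2460 nM

Both compounds were tested in a functional assay on OVCAR-5 cells (Homo sapiens) for inhibition, read by sulforhodamine B assay, with a stated time of 48 h; a lower number here means a stronger inhibitor of growth, a higher number a weaker inhibitor of growth. Of the two numbers, compound 2 gives the lower one with 2460 nM; compound 1 with 9330 nM stands higher, a gap beyond the usual scatter. The two differ in more than one place, so only their values can be compared.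

Compound 3, `COc1ccc(-c2nc3ncccn3c2/C=C/C(=O)c2cc(OC)c(OC)c(OC)c2)cc1`, keeps the core of compound 2 and changes only the substituted ring: methoxy in place of fluoro on an aromatic carbon. Among the compounds with values here, compound 1 also carries a methoxy group at this position, but its core differs, so no single-change step is available to guide the size of the effect. A small shift in this assay toward a higher number is expected, possibly none beyond the scatter. For compound 3 the estimated value is 4000 nM, with a range from 1500 nM to 12000 nM. The expected step of a 1.6-fold higher number from compound 2 to compound 3 (0.21 log units; within the scatter) is therefore a modest weakening.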

Compound 3, concentration for 50% growth inhibition: 1530 nM
Compound 3: middle estimate off by 2.6-fold (0.42 log units), on the high side; the measured number falls inside the stated range.
By their numbers in this assay, from the lowest: compounds 3 and 2 (each within the scatter of the next); then compound 1.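

In this assay, within the data shown here, the first single-change comparison at this position reads a 1.6-fold lower number from compound 2 to compound 3 (0.21 log units; within the scatter) when methoxy takes the place of fluoro on the aromatic carbon. The two compounds therefore cannot be told apart, so on this core the position, para to a large group, accepts either fluoro or methoxy with no change beyond the scatter. No measurement on hand explains why the two groups read alike.

The compounds shown leave open whether this tolerance extends to other groups on the same carbon, such as an amine, a carboxylic acid or a longer chain. They also leave open whether 4-fluorophenyl and 4-methoxyphenyl would read alike on the core of compound 1.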